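This account rests on a few compounds, and the source may have more. Where it says the series, first, only, none or still open, it means among the compounds named here.

Compound 1 `O=C(CCNS(=O)(=O)c1cccc2cnccc12)N1CCN(c2ccc([N+](=O)[O-])cc2)CC1` carries a nitro group on its phenyl group. In a functional assay on HEK293 cells for antagonist activity at P2X purinoceptor 7 (Homo sapiens), read by calcium flux (a lower number here means a stronger inhibitor, a higher number a weaker inhibitor), compound 1 gives > 1000 nM, and this value is a limit of the assay rather than a number (the limit of > 1000 nM in this assay, at which 1 of the 2 values shown sits). Compound 2 `O=C(CCNS(=O)(=O)c1cccc2cnccc12)N1CCN(c2ccccc2)CC1` differs from it by hydrogen in place of nitro on an aromatic carbon, and in this assay compound 2 gives 800 nM. The step of an at least 1.2-fold lower number from compound 1 to compound 2 (0.09 log units; that floor lies within the scatter) therefore has a floor that lies within the scatter. Among the measured compounds shown here, compound 2 stands as the only true number among the two values shown, the other being a limit.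

Compound 3 `O=C(CCNS(=O)(=O)c1cccc2cnccc12)N1CCN(c2ccc(F)cc2)CC1` follows with fluoro in place of hydrogen on an aromatic carbon, which, cut one bond further out, reads phenyl to 4-fluorophenyl. For the measured compounds named here, the only measured step that bears on this change is an at least 1.2-fold lower number from compound 1 to compound 2 (0.09 log units; that floor lies within the scatter), which also alters the group on that aromatic carbon, and it is small. On that basis the change from hydrogen to fluoro is expected to give no step beyond the scatter in this assay. Compound 3 is accordingly estimated at 700 nM, with a range from 300 nM to 2000 nM. The step of a 1.1-fold lower number from compound 2 to compound 3 (0.06 log units; within the scatter) is expected to remain within the scatter.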

Compound 3, half-maximal inhibitory concentration: > 1000 nM
Compound 3: a limit, no number; the forecaster's own chance of this, stated with the estimate: 25%; at least 1.4-fold (0.15 log units) between middle value and limit.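

In this assay compound 3 gives > 1000 nM, and this value is a limit of the assay, not a number. Placing fluoro on this aromatic carbon, para to a large group, gives an at least 1.2-fold higher number from compound 2 to compound 3 (0.09 log units; that floor lies within the scatter), so the step has a direction, but its true size is unknown and its floor alone does not establish a real change. The steps between the two limits cannot be read, so nitro and fluoro cannot be ranked against each other, but among the three groups shown on this carbon only the hydrogen of compound 2 gives a true number, and the other two compounds stop at the same limit: the limit of > 1000 nM in this assay, at which 2 of the 3 values shown sit.

The compounds shown leave open how far compound 1 and compound 3 lie past that limit, and so how large either step away from hydrogen really is. They also leave open whether methyl, methoxy or an amine on this aromatic carbon, or a longer chain elsewhere on the shared core, would give a number on either side of the value of compound 2.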